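Cyclohexyl for 4-Fluorophenyl on the Ring Amine Nitrogen

The compounds below may be only part of what the source reports. "The series", "measured", "known", "first", "only" and "open" are said of these compounds alone.

Compound 1 `Nc1ccccc1NC(=O)c1ccc(CSC(=S)N2CCN(c3ccc(F)cc3)CC2)cc1` is the strongest of the three measured compounds in a functional assay on HeLa cells (Homo sapiens) for antiproliferative activity, read by CCK-8 assay, with a stated time of 72 h, tested at 2 uM (a lower number here means a weaker effect, a higher number a stronger effect of the compound at the concentration tested), where compound 1 gives 60.8%. Its nearest neighbour, compound 2 `Nc1ccccc1NC(=O)c1ccc(CSC(=S)N2CCc3cc(Cl)ccc32)cc1`, gives 40.1% in this assay, a number beyond the scatter below that of compound 1, and compound 3 `CN(Cc1ccncc1)C(=S)SCc1ccc(C(=O)Nc2ccccc2N)cc1` gives 29.5%, the lowest of the three. Within the data shown here, the only step between measured compounds that differ in one place is a number 10.6 percentage points lower from compound 2 to compound 3 (beyond the scatter), a modest change at the thiocarbonyl carbon. Compound 4 `Nc1ccccc1NC(=O)c1ccc(CSC(=S)N2CCN(C3CCCCC3)CC2)cc1` differs from compound 1 at a different place: cyclohexyl in place of 4-fluorophenyl on an amine nitrogen in a ring. Among the measured compounds shown here, no measured step concerns the group on the amine nitrogen in a ring, so the record gives no direct guide to the size of this change. On that basis the step of a number 5.8 percentage points lower from compound 1 to compound 4 (within the scatter) is expected to be small, a lowering within the scatter rather than a change beyond it. Compound 4 is therefore estimated to give 55% in this assay, with a range from 35% to 72%.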

Compound 4, a percentage reported as inhibition, at one concentration (the size of the read-out at that concentration, not a potency): 30.6%
Beside the measured number, compound 4's estimate is 24.4 percentage points above it; the measured number lies below the stated range.
By their numbers in this assay, from the lowest: compounds 3, 4 and 2 (each within the scatter of the next, the first and the last beyond it); then compound 1.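

In this assay, the group on the amine nitrogen in a ring proves to matter: cyclohexyl in place of 4-fluorophenyl gives a number 30.2 percentage points lower from compound 1 to compound 4 (beyond the scatter), a large step and the first seen at this position. The loss appears even though the leaving and entering groups are both six-membered rings of carbon, with no hydrogen-bond donors or acceptors and no net charge, and they differ in aromatic character and in the fluorine. Nothing in the available evidence accounts for the size of this step.

The compounds shown leave open whether the aromatic ring alone carries the higher number or whether the fluorine contributes. An unsubstituted phenyl, a 4-methoxyphenyl or a pyridyl group on the same nitrogen would bear on that question, as would a small chain such as methyl.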